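Bromo to Fluoro on the Sulfonyl Ring, Tried Again

The source may hold more compounds than are shown below. What is called first, only, known or untested is meant among the compounds shown, and "the series" means these compounds.

Measured so far:
compound 1, `COc1cc(-c2nc(-c3ccccc3)[nH]c2-c2ccnc(NCCCNS(=O)(=O)c3ccc(Br)cc3)n2)ccc1F`, gives 33900 nM in a functional assay on LOX IMVI cells (Homo sapiens) for cytotoxicity, read by MTT assay, with a stated time of 24 h; on this read-out higher numbers stand for weaker inhibition and lower numbers for stronger inhibition
compound 2, `COc1cc(-c2nc(-c3ccccc3)[nH]c2-c2ccnc(NCCCNS(=O)(=O)c3ccc(F)cc3)n2)ccc1F`, gives 3960 nM in this assay
compound 3, `O=S(=O)(NCCCNc1nccc(-c2[nH]c(-c3ccccc3)nc2-c2ccc(Cl)c(O)c2)n1)c1ccc(Br)cc1`, gives 15500 nM in this assay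

Three compounds share a core and differ at two points. Compound 2 differs from compound 1 by one change on the sulfonyl ring: fluoro in place of bromo on an aromatic carbon. That change produced an 8.6-fold lower number from compound 1 to compound 2 (0.93 log units; beyond the scatter). Compound 3 keeps the bromo of compound 1 but carries a different aryl group on the five-membered ring: 4-chloro-3-hydroxyphenyl in place of 4-fluoro-3-methoxyphenyl on an aromatic carbon. Among the measured compounds shown here, that change gave a 2.2-fold lower number from compound 1 to compound 3 (0.34 log units; beyond the scatter), so compound 3 stands between the other two, with compound 2 remaining the one with the lowest number of the three.

Compound 4, `O=S(=O)(NCCCNc1nccc(-c2[nH]c(-c3ccccc3)nc2-c2ccc(Cl)c(O)c2)n1)c1ccc(F)cc1`, has not been measured. It differs from compound 3 by fluoro in place of bromo on an aromatic carbon. The place is described in the same words as for the change from compound 1 to compound 2, so this is the same change made on the core of compound 3. The change has only one precedent among these compounds, and that precedent is an 8.6-fold lower number from compound 1 to compound 2 (0.93 log units; beyond the scatter). Whether the core of compound 3 carries it equally well is not known from these data, so the expectation is held a little short of the precedent and given a wide range. Compound 4 is expected to show a step of a 6.2-fold lower number from compound 3 to compound 4 (0.79 log units; beyond the scatter). Compound 4 is estimated at 2500 nM, with a likely range from 800 nM to 8000 nM.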

Compound 4, half-maximal inhibitory concentration: 2300 nM
The estimate for compound 4 lay 1.1-fold (0.04 log units) above the measured number; measured number inside the range.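

In this assay, fluoro in place of bromo on the core of compound 3 gave a 6.7-fold lower number from compound 3 to compound 4 (0.83 log units; beyond the scatter), and this step kept the size it had on the core of compound 1: the same change on two cores in this assay, an 8.6-fold lower number (0.93 log units; beyond the scatter) from compound 1 to compound 2 and a 6.7-fold lower number (0.83 log units; beyond the scatter) from compound 3 to compound 4, 1.3-fold (0.10 log units) apart, within the scatter of two such steps The aryl change, read on the two fluoro compounds, gave a 1.7-fold lower number from compound 2 to compound 4 (0.24 log units; within the scatter), which also agrees with the same change on the two bromo compounds: the same change on two cores in this assay, a 2.2-fold lower number (0.34 log units; beyond the scatter) from compound 1 to compound 3 and a 1.7-fold lower number (0.24 log units; within the scatter) from compound 2 to compound 4, 1.3-fold (0.10 log units) apart, within the scatter of two such steps Each change therefore carried over between these two cores with its size intact, but this rests on a single pair of cores and a single cell assay, and it does not show that either step would hold on a core with a different aryl group or explain why the steps agree.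

The compounds shown leave open whether a group other than fluoro, such as chloro, methoxy or an amine, would give a similar step when it replaces bromo on the sulfonyl ring. They also leave open how the series would respond to a longer chain between the sulfonyl amino group and the shared core, or to a carboxylic acid on the phenyl of the five-membered ring.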